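This account rests on a few compounds, and the source may have more. Where it says the series, first, only, none or still open, it means among the compounds named here.

Compound 1 `CCOC(=O)c1c(C)nc(-c2cccc(C#N)c2)n1OCc1cccc(F)c1`: 22400 nM
Compound 2 `CCOC(=O)c1c(C)nc(-c2cccc(C#N)c2)n1OCc1cccc(Cl)c1`: 19400 nM
Compound 3 `CCOC(=O)c1c(C)nc(-c2cccc(C#N)c2)n1OCc1ccc(C)cc1`: 6310 nM

In a functional assay on a cell-free system (plasma, Oryctolagus cuniculus) for inhibition, with stated times of 5 min, 1 min and 6 min (a lower number here means a stronger inhibitor, a higher number a weaker inhibitor), compound 3 has the lowest number of the three, which makes it the strongest inhibitor so far. Compound 4 `CCOC(=O)c1c(C)nc(-c2cccc(C#N)c2)n1OCc1ccc(OC)cc1` has methoxy in place of methyl on an aromatic carbon, para to a large group (methoxy in place of methyl on an aromatic carbon). For the measured compounds named here, no measured step makes this exact swap. The closest evidence is modest: a 3.5-fold lower number from compound 1 to compound 3 (0.55 log units; beyond the scatter) and a 3.1-fold lower number from compound 2 to compound 3 (0.49 log units; beyond the scatter), while a 1.2-fold lower number from compound 1 to compound 2 (0.06 log units; within the scatter) stays within the scatter. These steps give a rough size but no direction, so no change beyond the scatter is expected. The expected step is a 1.1-fold higher number from compound 3 to compound 4 (0.05 log units; within the scatter). Compound 4 is estimated at 7000 nM, with an expected range of 2500 nM to 20000 nM.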

Compound 4, half-maximal inhibitory concentration: 6830 nM
Compound 4: middle estimate off by 1.0-fold (0.01 log units), on the high side; the range from low to high includes it.
By their numbers in this assay, from the lowest: compounds 3 and 4 (each within the scatter of the next); then compounds 2 and 1 (each within the scatter of the next).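

The step of a 1.1-fold higher number from compound 3 to compound 4 (0.03 log units; within the scatter) stays within the scatter in this assay, so at this carbon, para to a large group, methoxy and methyl cannot be told apart, even though methoxy adds an oxygen and a hydrogen-bond acceptor. The steps of a 2.8-fold lower number from compound 2 to compound 4 (0.45 log units; beyond the scatter) and a 3.3-fold lower number from compound 1 to compound 4 (0.52 log units; beyond the scatter) lie beyond the scatter, so 4-methoxyphenyl, like 4-methylphenyl, stands apart from the 3-chlorophenyl and 3-fluorophenyl groups. No measured evidence accounts for these results.

On these data alone, whether an amine, a carboxylic acid or a longer chain such as ethoxy on this aromatic carbon would give a similar number remains open. So does whether the gap to compounds 1 and 2 follows the substituent's place on the ring or its identity, since both differ in those steps.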